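Adding a chloro group to a biaryl choline kinase inhibitor

The source may report more compounds than this note shows. Statements on the series, on what has been measured and on what is new or still open speak of the compounds shown alone.

Of the compounds shown here, three have been measured in an assay on isolated protein for inhibition of choline kinase alpha (Homo sapiens), with a stated time of 30 min; a higher number here means a weaker inhibitor, a lower number a stronger inhibitor. Compound 1 `COC(=O)c1ccc(-c2ccc(CN3CCCN(C)CC3)cc2)cc1` gives 4950 nM, compound 2 `CN1CCCN(Cc2ccc(-c3ccc(CN4CCCN(C)CC4)cc3C#N)cc2)CC1` gives 66 nM, and compound 3 `CN1CCCN(Cc2ccc(-c3ccc(CN4CCCN(C)CC4)cc3)cc2)CC1` gives 457 nM, placing compound 3 second highest of the three numbers. Compound 4 `CN1CCCN(Cc2ccc(-c3ccc(CN4CCCN(C)CC4)c(Cl)c3)cc2)CC1` differs from compound 3 by chloro in place of hydrogen on an aromatic carbon. Within the data shown here, the closest precedent is the cyano step, where a 6.9-fold higher number from compound 2 to compound 3 (0.84 log units; beyond the scatter); the step of an 11-fold lower number from compound 1 to compound 3 (1.03 log units; beyond the scatter) concerns a different part of the core and bears less on this change. A small substituent on the shared core thus improved potency once, so for compound 4 the expected step is a 2.7-fold lower number from compound 3 to compound 4 (0.43 log units; beyond the scatter) in this assay, a modest improvement. Compound 4 is estimated at 170 nM, with a range from 55 nM to 520 nM.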

Compound 4, half-maximal inhibitory concentration: 268 nM
Beside the measured number, compound 4's estimate is 1.6-fold (0.20 log units) below it, within the range that was stated.
By their numbers in this assay, from the lowest: compound 2; then compounds 4 and 3 (each within the scatter of the next); then compound 1.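

Placing chloro on this aromatic carbon, ortho to a (4-methyl-1,4-diazepan-1-yl)methyl group, gives a 1.7-fold lower number from compound 3 to compound 4 (0.23 log units; within the scatter) in this assay, so this small substituent leaves the number indistinguishable from that of the unsubstituted core. The earlier compounds shown here gave no reading at this position, and it now appears to accept a chlorine atom without a clear loss or gain. No measurement here offers an explanation for this result. Going by these compounds, whether a methoxy group or an amine on the same carbon would move the number beyond the scatter remains open.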